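The compounds below may be only part of what the source reports. "The series", "measured", "known", "first", "only" and "open" are said of these compounds alone.

Of the compounds shown here, three that share one core have been measured in a functional assay on C8166 cells (Homo sapiens) for cytotoxicity, read by MTT assay; on this read-out lower numbers stand for higher toxicity in this test and higher numbers for lower toxicity in this test. In this test, compound 1 `Cc1cc(S(N)(=O)=O)ccc1NC(=O)COc1ccc(Cl)cc1NC(=O)c1ccccc1` gives 207000 nM. Compound 2 `Cc1cc(S(N)(=O)=O)ccc1NC(=O)COc1ccc(Cl)cc1NC(=O)c1ccccc1C` gives 67300 nM, and compound 3 `Cc1cccc(C(=O)Nc2cc(Cl)ccc2OCC(=O)Nc2ccc(S(N)(=O)=O)cc2C)c1` gives 52900 nM. Compound 2 therefore holds the second highest of the three numbers. Its smallest gap, a 1.3-fold lower number from compound 2 to compound 3 (0.10 log units; within the scatter), lies within the scatter, whereas its largest, a 3.1-fold lower number from compound 1 to compound 2 (0.49 log units; beyond the scatter), lies beyond it.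

The next compound to be measured is compound 4 `Cc1ccc(C(=O)Nc2cc(Cl)ccc2OCC(=O)Nc2ccc(S(N)(=O)=O)cc2C)cc1`, which has the same atoms as compound 2, joined differently: 4-methylphenyl in place of 2-methylphenyl on a carbonyl carbon.

Going by the values given here, the closest precedent is the exchange of 2-methylphenyl for 3-methylphenyl, a 1.3-fold lower number from compound 2 to compound 3 (0.10 log units; within the scatter), which stays within the scatter. Two further steps add a methyl to the unsubstituted ring: a 3.1-fold lower number from compound 1 to compound 2 (0.49 log units; beyond the scatter) and a 3.9-fold lower number from compound 1 to compound 3 (0.59 log units; beyond the scatter). Both are modest and beyond the scatter, but compound 4 keeps the methyl and differs from compound 2 only in where it sits. Among the compounds with values here, no step beyond the scatter is therefore expected in this assay, although only one such exchange has been measured. The expected step is a 1.1-fold lower number from compound 2 to compound 4 (0.05 log units; within the scatter). For compound 4, the estimated value is 60000 nM, with an expected range from 28000 nM to 130000 nM.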

Compound 4, half-maximal cytotoxic concentration: 54200 nM
The estimate for compound 4 lay 1.1-fold (0.04 log units) above the measured number, and the stated range covers the measured number.
By their numbers in this assay, from the lowest: compounds 3, 4 and 2 (each within the scatter of the next); then compound 1.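

Within this assay the methyl on the phenyl ring attached to the carbonyl carbon now has a third placement, and 4-methylphenyl stays within the scatter of both other placements (a 1.2-fold lower number from compound 2 to compound 4 (0.09 log units; within the scatter); a 1.0-fold higher number from compound 3 to compound 4 (0.01 log units; within the scatter)). Adding the methyl to the unsubstituted ring of compound 1 gives a modest step beyond the scatter in this case too (a 3.8-fold lower number from compound 1 to compound 4 (0.58 log units; beyond the scatter)), of the same order as the two steps already seen (a 3.1-fold lower number from compound 1 to compound 2 (0.49 log units; beyond the scatter); a 3.9-fold lower number from compound 1 to compound 3 (0.59 log units; beyond the scatter)), so across compounds 1 to 4 the lower number goes with having a methyl on this ring and not with where it sits, and no compound here goes against that. Nothing available offers an explanation for this pattern.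

The compounds shown leave open whether the step belongs to methyl itself or would also follow from another group on this ring, such as a chlorine, a methoxy or a longer chain like ethyl or propyl. They also leave open whether an amine or a carboxylic acid at these ring positions would prove as indifferent to placement as methyl has.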